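A few compounds are considered here, and "the series" means these few. Any claim that something is new, unique, unknown or untested is made for them only; others in the source may bear on it.

In a functional assay on HCT-116 cells (Homo sapiens) for antiproliferative activity, read by MTT assay, with a stated time of 2 days (a lower number here means a stronger inhibitor, a higher number a weaker inhibitor), compound 1 (`COc1cc(CCC(=O)Nc2ccc(C(=O)NO)cc2)ccc1OCc1ccccc1`) gives 120000 nM and compound 2 (`COc1cc(CCC(=O)Nc2ccc(C(=O)NO)cc2)ccc1OCc1cccs1`) gives 30000 nM as the half-maximal inhibitory concentration. For the measured compounds named here, compound 2 therefore holds the lower of the two numbers known so far, which makes it the stronger inhibitor of this pair. Compound 3 (`COc1cc(CCC(=O)Nc2ccc(C(=O)NO)cc2)ccc1OCc1ccccc1Br`) keeps the shared core and changes one group: 2-bromophenyl in place of thiophen-2-yl on a saturated chain carbon bound to an oxygen on an aromatic ring. Going by the values given here, only one measured step bears on this change, and it was modest: a 4.0-fold lower number from compound 1 to compound 2 (0.60 log units; beyond the scatter) when thiophen-2-yl took the place of phenyl on that same carbon. Compound 3 gives up thiophen-2-yl for a six-membered ring again, so a move back towards a higher number seems the likelier direction. Among the compounds with values here, no measured compound carries bromine, however, so this expectation is loose and the size of the move is uncertain. The expected change is a 2.0-fold higher number from compound 2 to compound 3 (0.30 log units; within the scatter) by this estimate. The estimate for compound 3 is 60000 nM in this assay with an expected range from 20000 nM to 150000 nM as its span.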

Compound 3, half-maximal inhibitory concentration: 100000 nM
Compound 3: the middle estimate sits 1.7-fold (0.22 log units) below what was measured, and the stated range covers the measured number.
By their numbers in this assay, from the lowest: compound 2; then compounds 3 and 1 (each within the scatter of the next).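

In this assay, replacing thiophen-2-yl with 2-bromophenyl on this saturated chain carbon gives a 3.3-fold higher number from compound 2 to compound 3 (0.52 log units; beyond the scatter), so the advantage of compound 2 is lost once a six-membered aromatic ring returns, even one that carries bromine. Comparing the bromine-bearing ring with the plain phenyl ring, bromo in place of hydrogen on an aromatic carbon gives a 1.2-fold lower number from compound 1 to compound 3 (0.08 log units; within the scatter), so this single added atom does not separate the two compounds in this assay, and among the three compounds only compound 2 stands apart from the others. Nothing measured here explains these differences.

From the compounds shown here alone, it remains open whether the lower number of compound 2 , 30000 nM, goes with the sulfur atom or with the five-membered ring, a question that a furan-2-yl group, with oxygen in place of sulfur, could help to answer. Going by these compounds, it is also open whether a chloro or methoxy group in place of the bromo group would likewise stay within the scatter of compound 1 , or would move the number in either direction.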